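A few compounds are considered here, and "the series" means these few. Any claim that something is new, unique, unknown or untested is made for them only; others in the source may bear on it.

The series keeps one shared core and differs only in the group on a single carbonyl carbon. Compound 3 `Cc1ccc(C(=O)Nc2ccc3nc(NC(=O)C4CCCCC4)sc3c2)cc1` gives 5.1 ug/mL in a functional assay on WI-38 VA13 cells (Homo sapiens) for cytotoxicity (a higher number here means that more compound is needed for the effect, a lower number that less compound is needed), the highest of the three numbers, while compound 2 `O=C(Nc1ccc2nc(NC(=O)C3CCCCC3)sc2c1)c1cccc(F)c1` gives 0.64 ug/mL and compound 1 `O=C(Nc1ccc2nc(NC(=O)C3CCCCC3)sc2c1)c1ccccc1F` gives 0.14 ug/mL. The steps among them, a 4.6-fold higher number from compound 1 to compound 2 (0.66 log units; beyond the scatter), an 8.0-fold higher number from compound 2 to compound 3 (0.90 log units; beyond the scatter) and a 36-fold higher number from compound 1 to compound 3 (1.56 log units; beyond the scatter), all exchange one substituted phenyl for another. Compound 4 `CC(=O)Nc1ccc2nc(NC(=O)C3CCCCC3)sc2c1` differs from compound 3 by methyl in place of 4-methylphenyl on a carbonyl carbon. For the measured compounds named here, no measured step removes the aromatic ring, so none bears directly on this change; the aryl swaps only show this position to be sensitive. For compound 4 a further rise in the number is expected, roughly a 2.4-fold higher number from compound 3 to compound 4 (0.37 log units; beyond the scatter). Compound 4 is therefore estimated at 12 ug/mL, with a range from 2.5 ug/mL to 60 ug/mL.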

Compound 4, half-maximal effective concentration: 2.7 ug/mL
Estimate against measurement, compound 4: 4.4-fold (0.65 log units) above, and the stated range covers the measured number.
By their numbers in this assay, from the lowest: compound 1; then compound 2; then compounds 4 and 3 (each within the scatter of the next).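

Methyl in place of 4-methylphenyl on this carbonyl carbon leaves the number in this assay unresolved, with a 1.9-fold lower number from compound 3 to compound 4 (0.28 log units; within the scatter) so the aromatic ring as such is not what separates these compounds. The same methyl compound stands apart from both fluorophenyl compounds, with a 4.2-fold higher number from compound 2 to compound 4 (0.63 log units; beyond the scatter) and a 19-fold higher number from compound 1 to compound 4 (1.29 log units; beyond the scatter) so the low numbers go with 2-fluorophenyl and 3-fluorophenyl, while compound 3 carries an aromatic ring without showing them. No measurement at hand accounts for these differences.

As far as these compounds go, it remains open whether a longer chain, an amine or a carboxylic acid on this carbonyl carbon would fall with compound 4 or with compound 1.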